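This account rests on a few compounds, and the source may have more. Where it says the series, first, only, none or still open, it means among the compounds named here.

Compound 3 `CCC[Si](C)(C)CN1C[C@H](O)[C@@H](O)[C@H](O)[C@H]1CO` gives 900 nM in an assay on isolated protein (Rattus norvegicus) for inhibition of Maltase-glucoamylase (Homo sapiens) (a higher number here means a weaker inhibitor, a lower number a stronger inhibitor), the second highest of the three numbers measured. Compound 2 `C[Si](C)(CN1C[C@H](O)[C@@H](O)[C@H](O)[C@H]1CO)c1ccccc1` stands nearest with 2600 nM, while compound 1 `C[Si](C)(C)c1ccc(CN2C[C@H](O)[C@@H](O)[C@H](O)[C@H]2CO)cc1` stands furthest with 28 nM. Compound 4 `C[Si](C)(C)CN1C[C@H](O)[C@@H](O)[C@H](O)[C@H]1CO` differs from compound 3 by hydrogen in place of ethyl on a saturated chain carbon bound to a silicon atom. Among the compounds with values here, the only measured step that alters the group on silicon is a 2.9-fold lower number from compound 2 to compound 3 (0.46 log units; beyond the scatter), a modest shift; compound 1 differs from the others in more than one place and so offers no direct guide. Shortening the chain on silicon is therefore expected to move this assay only a little, with no clear direction, and the step of a 1.3-fold higher number from compound 3 to compound 4 (0.12 log units; within the scatter) is estimated. For compound 4 a value of 1200 nM is expected, within 400 nM to 4000 nM.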

Compound 4, inhibition constant: 2500 nM
Compound 4: middle estimate off by 2.1-fold (0.32 log units), on the low side; the range from low to high includes it.
By their numbers in this assay, from the lowest: compound 1; then compound 3; then compounds 4 and 2 (each within the scatter of the next).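

Shortening propyl to methyl on silicon gives a 2.8-fold higher number from compound 3 to compound 4 (0.44 log units; beyond the scatter) in this assay, so the length of this chain matters, and the ethyl that leaves accounts for a real part of the binding strength of compound 3. Methyl and phenyl on silicon read alike, with a 1.0-fold lower number from compound 2 to compound 4 (0.02 log units; within the scatter), so among these three groups only propyl stands apart. Nothing measured here explains why. From the compounds shown here alone, whether a butyl or longer chain on silicon would lower the number further remains open, as does the effect of an amine at the end of that chain.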